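This account rests on a few compounds, and the source may have more. Where it says the series, first, only, none or still open, it means among the compounds named here.

Among the measured compounds shown here, compound 1 `Cc1ccc(-c2c3c(nc(C)c2[C@H](OC(C)(C)C)C(=O)O)CCN(c2ccccc2)C3)cc1` is one of three compounds measured in an ADME assay on the whole organism (Rattus norvegicus) for pharmacokinetics, read by LC-MS (on this read-out lower numbers stand for slow clearance and higher numbers for fast clearance), where compound 1 gives 24 mL/min/kg. Compound 3 `Cc1ccc(-c2c3c(nc(C)c2C(OC(C)(C)C)C(=O)O)CCN(Cc2ccccc2-c2ccccc2)C3)cc1` gives 24 mL/min/kg, level with compound 1 at the digits shown, and together these two are the lowest of the three numbers. Compound 2 `Cc1ccc(-c2c3c(nc(C)c2C(OC(C)(C)C)C(=O)O)CCN(CCCC2CCCC2)C3)cc1` gives 152 mL/min/kg, the highest of the three. For the measured compounds named here, the only single-point step among the measured compounds is a 6.3-fold lower number from compound 2 to compound 3 (0.80 log units; beyond the scatter), a modest step that lies beyond the scatter. Compound 4 `Cc1ccc(-c2c3c(nc(C)c2[C@H](OC(C)(C)C)C(=O)O)CCN(Cc2ccccc2)C3)cc1` is not yet measured; it differs from compound 1 by benzyl in place of phenyl on an amine nitrogen in a ring. Going by the values given here, no measured step repeats this change directly. The step from compound 2 to compound 3 shows that 2-phenylphenyl on a saturated chain carbon bound to an amine nitrogen in a ring sits at the low end of the series, and compound 1, with phenyl on an amine nitrogen in a ring, sits at the same low level. Benzyl in compound 4 shares features with both, so the expected step for compound 4 is a 1.2-fold higher number from compound 1 to compound 4 (0.07 log units; within the scatter), nothing beyond the scatter. The estimate for compound 4 in this assay is 28 mL/min/kg, between 12 mL/min/kg and 65 mL/min/kg.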

Compound 4, clearance: 21 mL/min/kg
The estimate for compound 4 lay 1.3-fold (0.12 log units) above the measured number; the measured number falls inside the stated range.
By their numbers in this assay, from the lowest: compounds 4, 1 and 3 (each within the scatter of the next); then compound 2.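

In this assay, benzyl in place of phenyl on an amine nitrogen in a ring gives a 1.1-fold lower number from compound 1 to compound 4 (0.06 log units; within the scatter), so on this core the change from phenyl to benzyl does not move clearance beyond the scatter. The earlier step, a 6.3-fold lower number from compound 2 to compound 3 (0.80 log units; beyond the scatter), compared two larger groups on a saturated chain carbon and did not show whether an aromatic ring bound directly to the nitrogen and one held on a carbon read alike; compounds 1 and 4 now show that they do, while compound 2, with its cyclopentyl ring, gives 152 mL/min/kg and stands apart. No measurement here explains why phenyl and benzyl read alike.

From the compounds shown here alone, whether a cyclohexyl ring on the same nitrogen would stay at this level remains open. So does the effect of a fluorine or methoxy group on the benzyl ring.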